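Ortho Methyl in Place of Ortho Fluoro

A few compounds are considered here, and "the series" means these few. Any claim that something is new, unique, unknown or untested is made for them only; others in the source may bear on it.

Measured compounds:
compound 1 `O=C(NCc1ccc(CNS(=O)(=O)c2ccccc2)cc1)c1ccc(CNc2ncccn2)cc1`: 1 nM
compound 2 `O=C(NCc1ccc(CNS(=O)(=O)c2ccccc2F)cc1)c1ccc(CNc2ncccn2)cc1`: 1000 nM

In an assay on MDA-MB-231 cells for binding affinity to C-X-C chemokine receptor type 4 (Homo sapiens), read by microscopy, with stated times of 10 min and 30 min (a lower number here means that less compound is needed, a higher number that more compound is needed for the effect), compound 1 gives 1 nM and compound 2 gives 1000 nM. Going by the values given here, compound 2 thus stands at the higher of the two numbers, with the only other compound far below it. Among the compounds with values here, the single measured step, a 1000-fold higher number from compound 1 to compound 2 (3.00 log units; beyond the scatter), shows what putting a fluoro onto that ring did.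

Compound 3 `Cc1ccccc1S(=O)(=O)NCc1ccc(CNC(=O)c2ccc(CNc3ncccn3)cc2)cc1` is not yet measured. It differs from compound 2 in one place: methyl in place of fluoro on an aromatic carbon. Within the data shown here, no measured step covers a methyl at this position, so the comparison rests on compound 2 alone. Because a 1000-fold higher number from compound 1 to compound 2 (3.00 log units; beyond the scatter) shows that a group at this position moved the number strongly upward, a methyl in the same place is expected to keep the number in the region of compound 2 rather than return it toward compound 1, though with wide uncertainty. Compound 3 is therefore estimated at 1000 nM, within 60 nM to 15000 nM, which means an expected step of no change at the digits printed from compound 2 to compound 3 (within the scatter).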

Compound 3, effective concentration (reported as EC, without a stated level of effect): 10 nM
Estimate against measurement, compound 3: 100-fold (2.00 log units) above, outside the stated range (below it).
By their numbers in this assay, from the lowest: compound 1; then compound 3; then compound 2.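

Replacing fluoro with methyl in this assay gives a 100-fold lower number from compound 2 to compound 3 (2.00 log units; beyond the scatter), so the sharp rise seen with fluoro does not follow from simply having one heavy atom on this ring carbon. The identity of the group matters, even though the two groups match in what can be counted here: one heavy atom each, with no hydrogen-bond donors or acceptors. Methyl is still not equivalent to hydrogen, giving a 10-fold higher number from compound 1 to compound 3 (1.00 log units; beyond the scatter), so among these three compounds the unsubstituted ring gives the lowest number, methyl an intermediate one and fluoro the highest.

No data shown here explain why two such small groups behave so differently at this position. On these data alone, it remains open whether a chloro, a methoxy or an amine at this position would fall nearer compound 1 or compound 2, and whether a methyl on another carbon of the same ring would give a similar result.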